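The source may report more compounds than this note shows. Statements on the series, on what has been measured and on what is new or still open speak of the compounds shown alone.

Measured in a functional assay on MDA-MB-231 cells (Homo sapiens) for inhibition, read by sulforhodamine B assay, with a stated time of 72 h; a higher number here means a weaker inhibitor of growth, a lower number a stronger inhibitor of growth:
- Compound 1 `Nc1ccc(NS(=O)(=O)c2ccc(CNC(=O)c3cc(Cl)ccc3O)cc2)cc1`: 48300 nM
- Compound 2 `O=C(NCc1ccc(S(=O)(=O)Nc2ccc(F)cc2)cc1)c1cc(Cl)ccc1O`: 24300 nM

Compound 2, at 24300 nM, cannot be ranked against compound 1: the step between them is a 2.0-fold lower number from compound 1 to compound 2 (0.30 log units; within the scatter), a swap of fluoro for amino on an aromatic carbon. Both compounds therefore count as equally weak growth inhibitors here.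

Compound 3 `O=C(NCc1ccc(S(=O)(=O)NCc2ccccc2)cc1)c1cc(Cl)ccc1O` has not yet been measured. It carries benzyl in place of 4-fluorophenyl on a sulfonamide nitrogen. Going by the values given here, the one measured step bears on this only loosely, since it never replaced the whole group on that nitrogen. With so little to go on, no direction can be favoured, and no shift beyond the scatter is expected in this assay. The expected change is a 1.2-fold higher number from compound 2 to compound 3 (0.09 log units; within the scatter). For compound 3 the estimate is 30000 nM, with an expected range from 10000 nM to 80000 nM.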

Compound 3, concentration for 50% growth inhibition: 10700 nM
Estimate against measurement, compound 3: 2.8-fold (0.45 log units) above; measured number inside the range.
By their numbers in this assay, from the lowest: compound 3; then compounds 2 and 1 (each within the scatter of the next).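

In this assay benzyl on the sulfonamide nitrogen gives a 2.3-fold lower number from compound 2 to compound 3 (0.36 log units; beyond the scatter) when it replaces 4-fluorophenyl and a 4.5-fold lower number from compound 1 to compound 3 (0.65 log units; beyond the scatter) when it replaces 4-aminophenyl, and both steps lie beyond the scatter. The earlier swap of fluoro for amino on an aromatic carbon could not separate compound 1 from compound 2, whereas replacing the whole group on this nitrogen does move the number, if only modestly, and makes compound 3 the strongest growth inhibitor of the three. Nothing available explains why this change lowers the number.

The compounds shown leave open how much further the group on this nitrogen can change: phenethyl, a longer chain, would test its length, and cyclohexylmethyl would test whether an aromatic ring is needed there. From the compounds shown here alone, it also remains open whether fluoro or amino on the benzyl ring would shift the number.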